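Difluorophenyl Amide Takes the Place of a Dimethylbenzyl Amide

A few compounds are considered here, and "the series" means these few. Any claim that something is new, unique, unknown or untested is made for them only; others in the source may bear on it.

Measured so far:
Compound 1, `COc1ccc2nc(C)cc(OCc3ccc4ccccc4n3)c2c1`: 21000 nM
Compound 2, `COc1ccc2nc(C)cc(OCC(=O)NCc3cc(C)cc(C)c3)c2c1`: 92000 nM
Compound 3, `COc1ccc2nc(C)cc(NCC(=O)Nc3cc(C)cc(C)c3)c2c1`: 204000 nM

In a physicochemical assay for solubility, in phosphate buffer, measured as kinetic solubility, with a stated time of 1 h, at pH 7.4 (a lower number here means a less soluble compound, a higher number a more soluble compound), compound 2 gives 92000 nM, the second highest of the three numbers. Its nearest neighbour, compound 3, gives 204000 nM, a gap beyond the scatter; the furthest, compound 1, gives 21000 nM, also beyond the scatter. Compound 4, `COc1ccc2nc(C)cc(OCC(=O)Nc3cc(F)cc(F)c3)c2c1`, is not yet measured. It differs from compound 2 in one place: 3,5-difluorophenyl in place of 3,5-dimethylbenzyl on an amide-type nitrogen. Among the compounds with values here, no step between measured compounds shows how this kind of change acts in this assay, so the expectation rests on compound 2 alone. The step is expected to stay within the scatter, with no direction favoured, as a 1.2-fold lower number from compound 2 to compound 4 (0.06 log units; within the scatter). Compound 4 is thus estimated at 80000 nM, with a range from 30000 nM to 220000 nM.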

Compound 4, solubility: 13000 nM
Beside the measured number, compound 4's estimate is 6.2-fold (0.79 log units) above it; the measured number lies below the stated range.
By their numbers in this assay, from the lowest: compounds 4 and 1 (each within the scatter of the next); then compound 2; then compound 3.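

In this assay, 3,5-difluorophenyl in place of 3,5-dimethylbenzyl on an amide-type nitrogen gives a 7.1-fold lower number from compound 2 to compound 4 (0.85 log units; beyond the scatter). Within the data shown here, this is the first single-place step, and it shows that the group on this nitrogen can by itself move the number beyond the scatter. Nothing measured here accounts for the size or direction of the step. The compounds shown leave open whether the step follows the fluorine atoms or the loss of the benzyl carbon, which change together. A 3,5-difluorobenzyl group on the same nitrogen would separate the two.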